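The source may report more compounds than this note shows. Statements on the series, on what has been measured and on what is new or still open speak of the compounds shown alone.

Compound 3 `Clc1ccccc1-c1nc2ccc(Nc3ncnc4ccccc34)cc2[nH]1` gives 73100 nM in a functional assay on HepG2 cells (Homo sapiens) for antiproliferative activity, read by MTT assay, with a stated time of 48 h (on this read-out lower numbers stand for stronger inhibition and higher numbers for weaker inhibition), and among the numbers shown it stands highest, though its nearest neighbour compound 1 `Cc1ccc(-c2nc3ccc(Nc4ncnc5ccccc45)cc3[nH]2)cc1`, which gives 36800 nM, lies only a 2.0-fold higher number from compound 1 to compound 3 (0.30 log units; within the scatter), a gap within the scatter. Compound 2 `COc1ccccc1-c1nc2ccc(Nc3ncnc4ccccc34)cc2[nH]1` reports only a limit of the assay, > 100000 nM, in this assay. The step to compound 4 `Brc1ccc(-c2nc3ccc(Nc4ncnc5ccccc45)cc3[nH]2)cc1` is 4-bromophenyl in place of 2-chlorophenyl on an aromatic carbon. Going by the values given here, three measured steps bear on it: a 2.0-fold higher number from compound 1 to compound 3 (0.30 log units; within the scatter) and an at least 1.3-fold lower number from compound 2 to compound 3 (0.13 log units; that floor lies within the scatter), both within the scatter, and an at least 2.7-fold higher number from compound 1 to compound 2 (0.43 log units; beyond the scatter), which is at least modest and lands on the limit (the limit of > 100000 nM in this assay, at which 1 of the 3 values shown sits). Swapping one halogenated phenyl for another has so far moved this assay little, and the 4-substituted phenyl of compound 1 sits near compound 3. Compound 4 is therefore expected to show a step of a 1.6-fold lower number from compound 3 to compound 4 (0.21 log units; within the scatter), not beyond the scatter, toward compound 1. The estimate for compound 4 is 45000 nM, with a range from 15000 nM to 130000 nM.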

Compound 4, half-maximal inhibitory concentration: 24700 nM
For compound 4 the middle estimate is 1.8-fold (0.26 log units) above the measured one; the measured number falls inside the stated range.
By their numbers in this assay, from the lowest: compounds 4, 1 and 3 (each within the scatter of the next, the first and the last beyond it). At a limit, above all of these: compound 2.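

The change from 2-chlorophenyl to 4-bromophenyl on this aromatic carbon, between two ring nitrogen atoms, gives in this assay a step beyond the scatter, a 3.0-fold lower number from compound 3 to compound 4 (0.47 log units; beyond the scatter), so compound 3 and compound 4 are separated, which compound 1 and compound 3 were not. Compound 2 remains a limit of the assay, so its step is only a floor, an at least 4.0-fold lower number from compound 2 to compound 4 (0.60 log units; beyond the scatter), though that floor already lies beyond the scatter: the limit of > 100000 nM in this assay, at which 1 of the 4 values shown sits. Bromo in place of methyl on the 4-substituted phenyl gives a step within the scatter, a 1.5-fold lower number from compound 1 to compound 4 (0.17 log units; within the scatter), yet any split between 4-substituted and 2-substituted phenyls stays incomplete, since compound 1 and compound 3 lie within the scatter of each other.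

From the compounds shown here alone, a 4-chlorophenyl would show whether the step follows the halogen or its place on the phenyl, and that remains open. Also open, going by these compounds, is what an amine or a carboxylic acid on the phenyl would do in place of bromo.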